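The compounds below may be only part of what the source reports. "The series", "measured", "known", "first", "only" and "open" are said of these compounds alone.

Measured compounds:
compound 1, `CCCCCCCCOC(=N)NC(=N)Nc1ccc(Cl)cc1`: 5.32
compound 2, `CC(C)OC(=N)NC(=N)Nc1ccc(Cl)cc1`: 2.64

In a physicochemical assay for lipophilicity, in phosphate buffer, measured as octanol-water partition, at pH 11.5 (a higher number here means a more lipophilic compound, a lower number a more polar compound), compound 2 gives the lower of these two numbers; compound 1 gives a value that lies higher by more than the usual scatter. Compound 3, `CCCCCCOC(=N)NC(=N)Nc1ccc(Cl)cc1`, has not been measured yet. It differs from compound 2 in one place: hexyl in place of isopropyl on an oxygen on an unsaturated carbon. With the chain growing, the value of compound 3 is expected to rise, by an estimated step of a number 1.66 log units higher from compound 2 to compound 3 (beyond the scatter), clearly beyond the scatter. For compound 3 the expected partition coefficient is therefore 4.3, with a range from 3.8 to 4.8.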

Compound 3, partition coefficient: 4.32
Beside the measured number, compound 3's estimate is 0.02 log units below it; the range from low to high includes it.
By their numbers in this assay, from the lowest: compound 2; then compound 3; then compound 1.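

In this assay, hexyl in place of isopropyl on an oxygen on an unsaturated carbon gives a large step, a number 1.68 log units higher from compound 2 to compound 3 (beyond the scatter), so this position responds strongly to the group it carries. Hydrogen in place of ethyl on a saturated chain carbon, six bonds along the chain from that oxygen, gives a modest step, a number 1.00 log units lower from compound 1 to compound 3 (beyond the scatter), and all three compounds now rise in order with chain size, with none going against it. No measurement shown gives a reason for these steps. The compounds shown leave open whether a longer chain than that of compound 1 would continue this order, and what an amine or a carboxylic acid on the chain would do.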